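Notes on a 2-hydroxyethyl substituent in the series

The source may hold more compounds than are shown below. What is called first, only, known or untested is meant among the compounds shown, and "the series" means these compounds.

In a functional assay on HeLa cells (Homo sapiens) for cytotoxicity, read by MTT assay (a higher number here means a weaker inhibitor, a lower number a stronger inhibitor), compound 1 (`CC(=O)OCCO[C@H](CC=C(C)C)C1=CC(=O)c2c(O)ccc(O)c2C1=O`) gives 41500 nM, compound 2 (`CCC(CO[C@H](CC=C(C)C)C1=CC(=O)c2c(O)ccc(O)c2C1=O)OC(C)=O`) gives 44000 nM and compound 3 (`CC(C)=CC[C@@H](OC(=O)C1CCOC1)C1=CC(=O)c2c(O)ccc(O)c2C1=O`) gives 73500 nM. Compound 3 therefore stands within the scatter of both other compounds, and the three numbers form a single band. The next compound to be measured is compound 4 (`CC(C)=CC[C@@H](OCCO)C1=CC(=O)c2c(O)ccc(O)c2C1=O`). The change is 2-hydroxyethyl in place of (oxolan-3-yl)carbonyl on an oxygen on a saturated carbon.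

Two measured steps exchange a group on this same oxygen: a 1.8-fold higher number from compound 1 to compound 3 (0.25 log units; within the scatter), with 2-acetoxyethyl leaving, and a 1.7-fold higher number from compound 2 to compound 3 (0.22 log units; within the scatter), with 2-acetoxybutyl leaving. Both lie within the scatter, as does a 1.1-fold higher number from compound 1 to compound 2 (0.03 log units; within the scatter), where ethyl is added on the chain. Among the compounds with values here, no measured compound carries the 2-hydroxyethyl group itself, so that group remains untested and the range has to stay wide. On these steps, no change beyond the scatter is expected in this assay, and the estimated step is a 1.5-fold lower number from compound 3 to compound 4 (0.17 log units; within the scatter). Compound 4 is expected at 50000 nM, with an estimated range from 22000 nM to 100000 nM.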

Compound 4, half-maximal inhibitory concentration: 18600 nM
The estimate for compound 4 lay 2.7-fold (0.43 log units) above the measured number, and the stated range ends above it.
By their numbers in this assay, from the lowest: compound 4; then compounds 1, 2 and 3 (each within the scatter of the next).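

In this assay, the oxygen on the saturated carbon proves sensitive to its substituent after all: 2-hydroxyethyl in place of (oxolan-3-yl)carbonyl gives a 4.0-fold lower number from compound 3 to compound 4 (0.60 log units; beyond the scatter), whereas the earlier exchanges on this oxygen stayed within the scatter. Within the data shown here, the comparison with the acetylated chains points the same way, with hydrogen in place of acetyl giving a 2.2-fold lower number from compound 1 to compound 4 (0.35 log units; beyond the scatter) and hydroxymethyl in place of 1-acetoxypropyl giving a 2.4-fold lower number from compound 2 to compound 4 (0.37 log units; beyond the scatter), so compound 4 now stands apart from the single band formed by compounds 1, 2 and 3 and has the lowest number of the four. No separate measurement bears on this result, and the steps give its size alone.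

Still open is whether the terminal hydroxyl itself or the chain that carries it accounts for the step, since no 2-methoxyethyl, 3-hydroxypropyl or 2-aminoethyl group stands among these compounds. Also open, from the compounds shown here alone, is whether removing the acetyl from compound 2, which would leave a 2-hydroxybutyl group on the same oxygen, would give a step of similar size.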